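Hydroxy on the saturated ring: series notes on compound 4

The source may report more compounds than this note shows. Statements on the series, on what has been measured and on what is new or still open speak of the compounds shown alone.

Of the compounds shown here, three have been measured so far. Compound 1 `Cc1ccccc1C1=NN(C(=O)c2ccncc2)C(C)(C)C1` gives 60 nM in an assay for inhibition of cholesterol 24-hydroxylase (Homo sapiens), using NADPH, with stated times of 15 min and 5 min; a lower number here means a stronger inhibitor, a higher number a weaker inhibitor. Compound 2 `COC(=O)c1cc(C)ccc1-c1ccncc1` gives 1900 nM in this assay. Compound 3 `Cc1ccc(-c2ccncc2)c(C(=O)N2CCC(Cc3ccccc3)CC2)c1` gives 110 nM in this assay. Compound 3 thus stands second highest of the three numbers: its nearest neighbour is compound 1, within the usual scatter, and its furthest is compound 2, whose number lies well beyond the scatter above it. Within the data shown here, no pair of measured compounds differs in a single place, so no step within the measured set can be read off.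

Compound 4 `Cc1ccc(-c2ccncc2)c(C(=O)N2CCC(Cc3ccccc3)C(O)C2)c1` has not yet been measured. It differs from compound 3 in one place: hydroxy in place of hydrogen on a saturated ring carbon. Among the measured compounds shown here, no measured step informs this change, so the step of a 1.4-fold higher number from compound 3 to compound 4 (0.13 log units; within the scatter) is expected to be small, at most a slight weakening and possibly none beyond the scatter. For compound 4 the estimate in this assay is 150 nM, with a range from 50 nM to 500 nM.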

Compound 4, half-maximal inhibitory concentration: 16 nM
The estimate for compound 4 lay 9.4-fold (0.97 log units) above the measured number; measured number outside the range, below it.
By their numbers in this assay, from the lowest: compound 4; then compounds 1 and 3 (each within the scatter of the next); then compound 2.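

In this assay, hydroxy in place of hydrogen on a saturated ring carbon, next to the ring atom that bears a benzyl group, gives a 6.9-fold lower number from compound 3 to compound 4 (0.84 log units; beyond the scatter) and so lies beyond the scatter. Among these compounds, this is the first single-place step, and it shows that this carbon of the six-membered non-aromatic ring takes a hydroxy group with a lower number, not a higher one. Nothing measured here accounts for the size of this step.

Going by these compounds, whether the drop is specific to hydroxy stays open: a methoxy group, an amine or a fluorine atom on the same carbon would separate hydroxy from other small groups. Also open, on these data alone, is whether hydroxy on the other saturated ring carbons gives a step of similar size.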